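Shrinking the Ring on the Thiocarbonyl Carbon: Compound 4

This account rests on a few compounds, and the source may have more. Where it says the series, first, only, none or still open, it means among the compounds named here.

Measured in a functional assay on MCF7 cells (Homo sapiens) for inhibition, read by MTT assay, with stated times of 18 h and 4 h; on this read-out higher numbers stand for weaker inhibition and lower numbers for stronger inhibition:
compound 1 `CCCCCCCCCCOP(=O)(O)OCCSC(=S)N1CCCC1`: 70000 nM
compound 2 `CCCCCCCCOP(=O)(O)OCCSC(=S)N1CCCCCC1`: 78000 nM
compound 3 `CCCCCCCCOP(=O)(O)OCCSC(=S)N1CCCCC1`: 26000 nM

Compound 3 holds the lowest number of the three, with compound 1 and compound 2 both giving higher numbers beyond the scatter. Compound 4 `CCCCCCCCOP(=O)(O)OCCSC(=S)N1CCCC1` differs from compound 3 in one place: pyrrolidin-1-yl in place of piperidin-1-yl on a thiocarbonyl carbon. Among the measured compounds shown here, the only measured step that bears on this change is a 3.0-fold lower number from compound 2 to compound 3 (0.48 log units; beyond the scatter), where a ring one atom smaller went with a lower number. Compound 1 also carries pyrrolidin-1-yl, yet with a longer chain, and its number lies above that of compound 3, so the trend is not clean. Compound 4 is therefore expected to give roughly a 1.3-fold higher number from compound 3 to compound 4 (0.13 log units; within the scatter), with an estimate of 35000 nM and a range from 12000 nM to 100000 nM.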

Compound 4, half-maximal inhibitory concentration: 53000 nM
Compound 4: middle estimate off by 1.5-fold (0.18 log units), on the low side; the range from low to high includes it.
By their numbers in this assay, from the lowest: compound 3; then compounds 4, 1 and 2 (each within the scatter of the next).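

In this assay, the ring on the thiocarbonyl carbon shows no one-way trend with size: a 2.0-fold higher number from compound 3 to compound 4 (0.31 log units; beyond the scatter) sets piperidin-1-yl apart from the smaller pyrrolidin-1-yl as well as from the larger azepan-1-yl. The two other rings are not separated, with a 1.5-fold lower number from compound 2 to compound 4 (0.17 log units; within the scatter), and the chain change also gives no separation, with a 1.3-fold lower number from compound 1 to compound 4 (0.12 log units; within the scatter). Nothing available explains why piperidin-1-yl stands apart. Still open, going by these compounds, is whether an open-chain diethylamino group on that carbon, or piperidin-1-yl paired with a longer chain, would match compound 3.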